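Benzyloxy versus carbamoyl side chains on the shared core

The compounds below may be only part of what the source reports. "The series", "measured", "known", "first", "only" and "open" are said of these compounds alone.

Of the compounds shown here, three on the shared core have been tested in a functional assay on HEK293 cells for agonist activity at G-protein coupled receptor 39 (Homo sapiens), read by scintillation proximity assay and inositol phosphate accumulation, with a stated time of 75 min; on this read-out lower numbers stand for an effect already at smaller amounts and higher numbers for an effect only at larger amounts of compound. Compound 1 `Cc1nn(-c2ncnc3nc[nH]c23)c2c1C(OCc1ccccc1C#N)CC(=O)N2` gives 127 nM. Compound 2 `Cc1nn(-c2ncnc3nc[nH]c23)c2c1C(OCCn1nccc1C)CC(=O)N2` gives 1620 nM. Compound 3 `Cc1nn(-c2ncnc3nc[nH]c23)c2c1C(C(=O)N(C)c1nccs1)CC(=O)N2` gives 3300 nM, the highest of the three numbers; the nearest is compound 2, the furthest compound 1. The measured steps are a 13-fold higher number from compound 1 to compound 2 (1.11 log units; beyond the scatter), a 26-fold higher number from compound 1 to compound 3 (1.41 log units; beyond the scatter) and a 2.0-fold higher number from compound 2 to compound 3 (0.31 log units; beyond the scatter).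

Compound 4 `Cc1nn(-c2ncnc3nc[nH]c23)c2c1C(OCc1ccc(F)cc1)CC(=O)N2` is not yet measured. Relative to compound 3 the change is (4-fluorobenzyl)oxy in place of methyl(1,3-thiazol-2-yl)carbamoyl on a saturated ring carbon. This returns to the ether-linked benzyl side chain of compound 1, with a fluorine on the ring in place of the nitrile. Going by the values given here, the step that bears most directly is the one from compound 1 to compound 3, where the carbamoyl in place of the benzyloxy gave a 26-fold higher number from compound 1 to compound 3 (1.41 log units; beyond the scatter); the step from compound 1 to compound 2, a 13-fold higher number from compound 1 to compound 2 (1.11 log units; beyond the scatter), shows that a different ether-linked group still costs a good deal. Among the compounds with values here, no measured pair covers the fluorine-for-nitrile swap itself, so some uncertainty remains on that part.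

Compound 4 is therefore expected to show a large step down in this assay, a 15-fold lower number from compound 3 to compound 4 (1.18 log units; beyond the scatter), because the reverse of a 26-fold higher number from compound 1 to compound 3 (1.41 log units; beyond the scatter) should be recovered in the main. The estimate for compound 4 is 220 nM, with a range from 60 nM to 800 nM.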

Compound 4, half-maximal effective concentration: 126 nM
The estimate for compound 4 lay 1.7-fold (0.24 log units) above the measured number; the range from low to high includes it.
By their numbers in this assay, from the lowest: compounds 4 and 1 (each within the scatter of the next); then compound 2; then compound 3.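

Replacing 2-cyanophenyl with 4-fluorophenyl on the saturated chain carbon bound to the oxygen in this assay gives a 1.0-fold lower number from compound 1 to compound 4 (0.00 log units; within the scatter), so among these two benzyl ethers the nitrile is not needed to hold the value, and a ring fluorine serves equally well. The standing of the benzyl ethers also no longer rests on compound 1 alone, as a second such ether also separates clearly from the carbamoyl side chain (a 26-fold lower number from compound 3 to compound 4 (1.42 log units; beyond the scatter)) and from the ether-linked (5-methyl-1H-pyrazol-1-yl)methyl group (a 13-fold lower number from compound 2 to compound 4 (1.11 log units; beyond the scatter)). No supporting data accompany these results, so they describe the side-chain differences without accounting for them.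

On these data alone, whether a benzyl group with an unsubstituted phenyl ring, or one carrying a chlorine or a methoxy group, stays level with compound 1 and compound 4 remains open. So does the role of the linking oxygen itself, which a comparison with an all-carbon chain or an amine linker at this saturated ring carbon would address.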